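Compound 3 to compound 4: morpholine amide to acid

A few compounds are considered here, and "the series" means these few. Any claim that something is new, unique, unknown or untested is made for them only; others in the source may bear on it.

In a functional assay on KB cells (Homo sapiens) for inhibition, read by sulforhodamine B assay, with a stated time of 72 h (on this read-out higher numbers stand for weaker inhibition of growth and lower numbers for stronger inhibition of growth), compound 3 `O=C(CCc1ccncc1-c1ccc2ccccc2c1)N1CCOCC1` gives > 10000 nM, a limit and not a number. Compound 1 `O=C(O)/C=C/c1ccncc1-c1ccc2ccccc2c1`, which also carries a carboxy group, gives > 10000 nM, again a limit. Compound 2 `Cn1ncc2cc(-c3cnccc3/C=C/C(=O)O)ccc21` gives > 10000 nM, likewise a limit. Going by the values given here, the series therefore stands at the limit of > 10000 nM in this assay, at which 3 of the 3 values shown sit, and no measured step is available.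

Compound 4 `O=C(O)CCc1ccncc1-c1ccc2ccccc2c1` differs from compound 3 by hydroxy in place of morpholin-4-yl on a carbonyl carbon.

In this assay, no step beyond the scatter is expected in either direction, and the expectation rests on compound 1 at > 10000 nM, a limit. The expected a number no higher from compound 3 to compound 4 (the limit leaves the size open) is correspondingly small. Compound 4 is estimated at 10000 nM, with an expected range of 5000 nM to 20000 nM.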

Compound 4, concentration for 50% growth inhibition: > 10000 nM
Compound 4: no number, only a limit; the forecaster's own chance of this, stated with the estimate: 85%; the middle value sits exactly at the limit.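

Neither the step from compound 3 to compound 4 nor the one from compound 1 to compound 4 can be read, as each compound gives only a limit: the limit of > 10000 nM in this assay, at which 4 of the 4 values shown sit.

On these data alone, whether hydroxy in place of morpholin-4-yl, or 2-carboxyethyl in place of 2-carboxyethenyl, changes growth inhibition at all remains open.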